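The source may report more compounds than this note shows. Statements on the series, on what has been measured and on what is new or still open speak of the compounds shown alone.

Compound 1 `CC(C)CCn1cnc2c(Nc3cccc(O)c3)nc(N[C@H]3CC[C@H](N)CC3)nc21` gives 60 nM in a functional assay on EOL1 cells (Homo sapiens) for inhibition, read by fluorescence, with a stated time of 72 h; on this read-out lower numbers stand for stronger inhibition of growth and higher numbers for weaker inhibition of growth.
Compound 2 `CCCCn1cnc2c(Nc3cccc(Cl)c3)nc(N[C@H]3CC[C@H](N)CC3)nc21` gives 160 nM in this assay.
Compound 3 `COc1ccc(Nc2nc(N[C@H]3CC[C@H](N)CC3)nc3c2ncn3CCC(C)C)c(OC)c1` gives 630 nM in this assay.

Among these three, compound 3 stands at the highest number in this assay, its nearest neighbour being compound 2, which sits beyond the scatter below it, and compound 1 lying further down still. For the measured compounds named here, the one measured step that touches compound 3 directly is an 11-fold higher number from compound 1 to compound 3 (1.02 log units; beyond the scatter), a large rise that accompanies the swap of the aryl group on the nitrogen on the aromatic ring.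

The next compound, compound 4 `CC(C)CCn1cnc2c(Nc3cccc(Cl)c3)nc(N[C@H]3CC[C@H](N)CC3)nc21`, undoes that aryl change in a different direction: 3-chlorophenyl in place of 2,4-dimethoxyphenyl on a nitrogen on an aromatic ring. Going by the values given here, this step has no exact measured counterpart, but two things bear on it. First, the step from compound 1 to compound 3 shows that removing the 2,4-dimethoxyphenyl for a smaller aryl group can lower the number sharply. Second, the 3-chlorophenyl is already carried by compound 2, which differs from compound 4 only in the chain on the other ring nitrogen; in this assay compound 2 gives 160 nM. Compound 4 is therefore expected to come out well below compound 3, with an estimated step of a 5.3-fold lower number from compound 3 to compound 4 (0.72 log units; beyond the scatter). The estimate for compound 4 in this assay is 120 nM, with a range from 40 nM to 400 nM.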

Compound 4, concentration for 50% growth inhibition: 60 nM
Beside the measured number, compound 4's estimate is 2.0-fold (0.30 log units) above it; the measured number falls inside the stated range.
By their numbers in this assay, from the lowest: compounds 1 and 4 (each within the scatter of the next); then compound 2; then compound 3.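

Compound 4 shows that the high number of compound 3 does not belong to every aryl group on this nitrogen: 3-chlorophenyl in place of 2,4-dimethoxyphenyl gives an 11-fold lower number from compound 3 to compound 4 (1.02 log units; beyond the scatter) in this assay, while chloro in place of hydroxy on an aromatic carbon gives no change at the digits printed from compound 1 to compound 4 (within the scatter), so these two groups cannot be told apart here. With 3-chlorophenyl held constant, the chain also proves to matter, since methyl in place of hydrogen on a saturated chain carbon bound to two saturated chain carbons gives a 2.7-fold lower number from compound 2 to compound 4 (0.43 log units; beyond the scatter), a modest step but one that compound 1 and compound 3 alone could not show. Nothing available explains why either the aryl group or the chain shifts the number in this way.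

The compounds shown leave open whether the rise seen with 2,4-dimethoxyphenyl follows from one methoxy group or needs both, since that group enters whole. Also open, from the compounds shown here alone, is how a fluoro or an amine in place of the chloro, or a longer chain in place of the present one, would read in this assay.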